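Ring swap on the sulfonyl-bound carbon: compound 2 to 4

A few compounds are considered here, and "the series" means these few. Any claim that something is new, unique, unknown or untested is made for them only; others in the source may bear on it.

Compound 2 `O=S(=O)(CC1=NCCS1)c1c(-c2ccc(Cl)cc2)noc1-c1ccc(Cl)cc1` is reported in a functional assay, read by Griess assay, with a stated time of 150 min, tested at 100 ug/mL (a higher number here means a stronger effect of the compound at the concentration tested, a lower number a weaker effect), as "not active" (no number reported), with no number given; it is one of two entries in the series without a single value and cannot be placed on the numeric scale at all. Compound 1 `O=S(=O)(CC1=NCCS1)C1C(c2ccccc2)=NN(c2ccccc2)C1c1ccccc1` likewise returns "not active" (no number reported) in this assay. For the measured compounds named here, the only numeric point is compound 3 `O=S(=O)(CC1=NCCO1)c1n[nH]cc1-c1ccccc1`, which in this assay reaches 57.5%. Going by the values given here, no step between measured compounds that differ in one place is available.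

Compound 4 `O=S(=O)(CC1=NCCO1)c1c(-c2ccc(Cl)cc2)noc1-c1ccc(Cl)cc1` differs from compound 2 by a group of 5 heavy atoms (3 carbon, 1 nitrogen, 1 oxygen; one five-membered non-aromatic ring with 2 hetero atoms) in place of a group of 5 heavy atoms (3 carbon, 1 nitrogen, 1 sulfur; one five-membered non-aromatic ring with 2 hetero atoms), on a saturated chain carbon bound to a sulfonyl sulfur. Compound 3 carries the same entering group, though on a different core; compound 3 and compound 4 differ in more than one place, so nothing can be read between them as a step.

Because compound 2 gives "not active" (no number reported) and no number, the step to compound 4 in this assay cannot be sized as a difference; a rise beyond the scatter is possible but not established, and a result that again returns no number is about as likely as not. Compound 4 is estimated at 20% in this assay, with an expected range of 0% to 55%.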

Compound 4, a percentage reported as activity, at one concentration (the size of the read-out at that concentration, not a potency): "not active" (no number reported)
For compound 4 the study gives words and no number; the estimate stays without a comparison.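

In this assay, for the compounds shown here, compound 2 gives "not active" (no number reported) and compound 4 gives "not active" (no number reported), so no step between them can be read. No supporting evidence bears on this result. The compounds shown leave open whether exchanging these two rings, on a saturated chain carbon bound to a sulfonyl sulfur, alters the read-out on any core that returns a number.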